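The source may report more compounds than this note shows. Statements on the series, on what has been measured and on what is new or still open speak of the compounds shown alone.

Compound 1 `Brc1ccc(Nc2nc(-n3cnc4ccccc43)cs2)cc1`: > 100000 nM
Compound 2 `Cc1nc2ccccc2n1-c1csc(Nc2ccc(Br)cc2)n1`: 90 nM

In a functional assay on RKO cells (Homo sapiens) for cytotoxicity, read by resazurin assay, with a stated time of 72 h (a lower number here means a stronger inhibitor, a higher number a weaker inhibitor), compound 1 reaches only a limit, > 100000 nM. Going by the values given here, compound 2, at 90 nM, holds the only actual number. Compound 3 `Cc1nc2ccccc2n1-c1csc(Nc2ccc(S(N)(=O)=O)cc2)n1` has sulfamoyl in place of bromo on an aromatic carbon, para to a large group (sulfamoyl in place of bromo on an aromatic carbon). Among the compounds with values here, the one measured step, an at least 1100-fold lower number from compound 1 to compound 2 (3.04 log units; beyond the scatter), is large but is a methyl change elsewhere, so it gives no direct size for this swap and only warns that single changes can matter greatly here. A moderate move towards a weaker inhibitor is expected, with wide uncertainty. The expected change is a 6.7-fold higher number from compound 2 to compound 3 (0.82 log units; beyond the scatter). For compound 3 the estimated value is 600 nM, with an expected range from 80 nM to 6000 nM.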

Compound 3, half-maximal inhibitory concentration: 45000 nM
Compound 3: the middle estimate sits 75-fold (1.88 log units) below what was measured; measured number outside the range, above it.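

Sulfamoyl in place of bromo, on an aromatic carbon para to a large group, gives a 500-fold higher number from compound 2 to compound 3 (2.70 log units; beyond the scatter). Going by these compounds alone, this is the first sign that the aryl end of the molecule, not only the methyl site on the other side, governs the number in this assay. Compound 3 still gives an actual number and not a limit, so this step has a measured size, unlike the step from compound 1: the limit of > 100000 nM in this assay, at which 1 of the 3 values shown sits.

The compounds shown do not separate the loss of bromo from the arrival of sulfamoyl. Going by these compounds, whether chloro, methoxy or an amine at this place would keep the number of compound 2 remains open.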